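Methoxy for Methyl on the Aryl Triazole

The compounds below may be only part of what the source reports. "The series", "measured", "known", "first", "only" and "open" are said of these compounds alone.

Three compounds share one core. Compound 1 `CC(C)n1ncc2c(C(=O)NCc3cn(-c4ccc(F)cc4)nn3)cccc21`, compound 2 `CC(C)n1ncc2c(C(=O)NCc3cn(-c4ccc([N+](=O)[O-])cc4)nn3)cccc21` and compound 3 `Cc1cccc(-n2cc(CNC(=O)c3cccc4c3cnn4C(C)C)nn2)c1` have each been tested in a functional assay on MGC-803 cells (Homo sapiens) for inhibition, read by MTT assay, with a stated time of 72 h; a lower number here means a stronger inhibitor, a higher number a weaker inhibitor. Compound 1 gives only a limit, > 40000 nM. Compound 2 likewise gives only a limit, > 40000 nM. Compound 3 also stands at a limit, > 40000 nM. All three values sit at the limit of > 40000 nM in this assay, at which 3 of the 3 values shown sit. The steps a step that the two limits leave unreadable from compound 1 to compound 2, a step that the two limits leave unreadable from compound 1 to compound 3 and a step that the two limits leave unreadable from compound 2 to compound 3 therefore have no readable size, and none of them shows a direction. Compound 4 `COc1ccc(-n2cc(CNC(=O)c3cccc4c3cnn4C(C)C)nn2)cc1` carries the change (4-methoxyphenyl in place of 3-methylphenyl on an aromatic nitrogen). Within the data shown here, with no measured step readable, no direction beyond the scatter is expected for a step that the limit leaves unreadable from compound 3 to compound 4. Compound 4 is expected at 50000 nM, between 15000 nM and 200000 nM, most probably again reported only as a limit.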

Compound 4, half-maximal inhibitory concentration: > 40000 nM
Compound 4 ended at the assay's limit (the forecaster's own chance of this, stated with the estimate: 85%); the middle value is on the limit's open side.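

Among these compounds, compound 4 also gives only a limit, so no step from compound 1, compound 2 or compound 3 to compound 4 can be read: the limit of > 40000 nM in this assay, at which 4 of the 4 values shown sit. The compounds shown leave open whether changing the aryl group on the shared core alters the result in this assay.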